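A few compounds are considered here, and "the series" means these few. Any claim that something is new, unique, unknown or untested is made for them only; others in the source may bear on it.

Compound 2, `CCCCCOC(=O)N1CCN(C(=O)[C@H](CCC(=O)O)NC(=O)c2cc(N3CCC(C(=O)N(CC)CC)CC3)nc(-c3ccccc3)n2)CC1`, stands at the lower of the two numbers recorded so far: in an in vivo ADME assay on the whole organism (strain Sprague-Dawley) for pharmacokinetics, with Rattus norvegicus as the target (on this read-out higher numbers stand for fast clearance and lower numbers for slow clearance), compound 2 gives 6 mL/min/kg, while compound 1, `CCCCCOC(=O)N1CCN(C(=O)[C@H](CCC(=O)O)NC(=O)c2cc(N3CCC(COC)CC3)nc(-c3ccccc3)n2)CC1`, gives 14 mL/min/kg. For the measured compounds named here, the one measured step, a 2.3-fold lower number from compound 1 to compound 2 (0.37 log units; beyond the scatter), concerns a change at the same saturated ring carbon. Compound 3, `CCCCCOC(=O)N1CCN(C(=O)[C@H](CCC(=O)O)NC(=O)c2cc(N3CCC(CNC)CC3)nc(-c3ccccc3)n2)CC1`, differs from compound 2 by (methylamino)methyl in place of diethylcarbamoyl on a saturated ring carbon. Going by the values given here, no measured step covers (methylamino)methyl, so only the modest size of the known step guides the expectation, and a small rise back toward compound 1 is expected for compound 3, a 1.7-fold higher number from compound 2 to compound 3 (0.22 log units; within the scatter). Compound 3 is therefore estimated at 10 mL/min/kg, between 5 mL/min/kg and 20 mL/min/kg.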

Compound 3, clearance: 31 mL/min/kg
Compound 3: the middle estimate sits 3.1-fold (0.49 log units) below what was measured, and the stated range ends below it.
By their numbers in this assay, from the lowest: compound 2; then compound 1; then compound 3.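

In this assay this saturated ring carbon turns out to move the number upward as well as downward: the change to (methylamino)methyl brings a 5.2-fold higher number from compound 2 to compound 3 (0.71 log units; beyond the scatter) and puts compound 3 at the top of the three. Within the side chain alone, methylamino in place of methoxy brings a 2.2-fold higher number from compound 1 to compound 3 (0.35 log units; beyond the scatter) and so is enough on its own to shift the number. Nothing at hand accounts for either shift. The compounds shown leave open whether a dimethylamino group on the same chain carbon, or a hydroxyl group there, would stay near compound 3 or fall back toward compound 1.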